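Chain length on the aromatic amine of the triazolopyrimidine-type core

This account rests on a few compounds, and the source may have more. Where it says the series, first, only, none or still open, it means among the compounds named here.

Measured so far in an assay on isolated protein for binding affinity to adenosine receptor A1 (Bos taurus); on this read-out higher numbers stand for weaker inhibition and lower numbers for stronger inhibition:
compound 1 `CCCNc1nc(-c2ccccc2)nc2c1nnn2Cc1ccccc1F` gives 3200000 nM
compound 2 `CNc1nc(-c2ccccc2)nc2c1nnn2Cc1ccccc1F` gives 25000000 nM

Going by the values given here, compound 2 stands at the highest of the two numbers; its nearest neighbour is compound 1, and the one measured step between them, a 7.8-fold higher number from compound 1 to compound 2 (0.89 log units; beyond the scatter), shows that shortening the chain on the amine to a bare hydrogen is accompanied by a modest rise in the number.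

Compound 3 `OCCNc1nc(-c2ccccc2)nc2c1nnn2Cc1ccccc1F` is not yet measured. Its difference from compound 2 is hydroxymethyl in place of hydrogen on a saturated chain carbon bound to a nitrogen on an aromatic ring. Among the compounds with values here, this reverses the direction of the only measured step: the chain on the amine is lengthened again, now to a 2-hydroxyethyl group, which carries one hydrogen-bond donor and one acceptor that the propyl chain of compound 1 lacks. The step of a 7.8-fold higher number from compound 1 to compound 2 (0.89 log units; beyond the scatter) is the only one that bears on it, and it suggests that the lengthening should lower the number. Because the added group is not the same as the one removed in a 7.8-fold higher number from compound 1 to compound 2 (0.89 log units; beyond the scatter), a somewhat smaller step is expected, but in the same downward direction. For compound 3 a step of a 3.6-fold lower number from compound 2 to compound 3 (0.55 log units; beyond the scatter) is expected, giving an estimate of 7000000 nM in this assay, between 2500000 nM and 20000000 nM.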

Compound 3, inhibition constant: 54000000 nM
Compound 3: middle estimate off by 7.7-fold (0.89 log units), on the low side; the whole stated range lies below it.
By their numbers in this assay, from the lowest: compound 1; then compound 2; then compound 3.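

In this assay, lengthening the methyl of compound 2 to 2-hydroxyethyl does not move the number down towards that of the propyl-bearing compound 1; instead it gives a 2.2-fold higher number from compound 2 to compound 3 (0.33 log units; beyond the scatter), so chain length alone does not set the number at this position. The comparison at the far end of the chain is sharper: hydroxy in place of methyl on a saturated chain carbon, two bonds along the chain from a nitrogen on an aromatic ring, gives a 17-fold higher number from compound 1 to compound 3 (1.23 log units; beyond the scatter), the largest step among the three compounds, and it leaves compound 3 with the highest number of the series. Nothing available on these compounds accounts for this rise.

Still open, going by these compounds, is whether the rise belongs to hydroxy specifically, or whether a methoxy group or an amine at the end of the same chain would raise the number too. Also open, on these data alone, is whether a butyl chain or a longer one on the amine would lower the number further than the propyl chain of compound 1 does, or whether the trend stops there.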